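Changing One Ring Group on a Shared Core

This account rests on a few compounds, and the source may have more. Where it says the series, first, only, none or still open, it means among the compounds named here.

compound 1 `O=C(CCN1CCN(c2ccc(C(F)(F)F)cc2)CC1)c1ccc(Br)cc1` gives 78800 nM
compound 2 `O=C(CCN1CCN(c2ccc(C(F)(F)F)cc2)CC1)c1ccc(F)c(Cl)c1` gives 74500 nM

These numbers come from an ADME assay on Vero cells (Chlorocebus sabaeus) for cytotoxicity, read by resazurin assay, with a stated time of 72 h (a lower number here means a stronger inhibitor, a higher number a weaker inhibitor), and compound 2 sits level with compound 1 there. Among the measured compounds shown here, only one step has been measured: a 1.1-fold lower number from compound 1 to compound 2 (0.02 log units; within the scatter) and it lies within the scatter, at the same place that changes next. Compound 3 `O=C(CCN1CCN(c2ccc(C(F)(F)F)cc2)CC1)c1ccc(C(F)(F)F)cc1` carries 4-(trifluoromethyl)phenyl in place of 3-chloro-4-fluorophenyl on a carbonyl carbon. For the measured compounds named here, with a 1.1-fold lower number from compound 1 to compound 2 (0.02 log units; within the scatter) as the only guide, no change beyond the scatter is expected in this assay from this swap. The expected step is small (a 1.0-fold lower number from compound 2 to compound 3 (0.01 log units; within the scatter)) on this evidence. Compound 3 is estimated at 72000 nM with an expected range from 36000 nM to 140000 nM in repeat measurements.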

Compound 3, half-maximal inhibitory concentration: 49200 nM
Compound 3: the middle estimate sits 1.5-fold (0.17 log units) above what was measured; the range from low to high includes it.
By their numbers in this assay, from the lowest: compounds 3, 2 and 1 (each within the scatter of the next).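

Two further swaps at this position also stay within the scatter in this assay: replacing 3-chloro-4-fluorophenyl gives a 1.5-fold lower number from compound 2 to compound 3 (0.18 log units; within the scatter), and trifluoromethyl in place of bromo on an aromatic carbon gives a 1.6-fold lower number from compound 1 to compound 3 (0.20 log units; within the scatter). Thus, all three halogen-bearing phenyl groups on the carbonyl carbon read alike here, including the two with the same ring and a single group changed. No measured property is available to account for this. As far as these compounds go, whether a phenyl ring carrying an amine or a carboxylic acid would read alike remains open.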